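The source may report more compounds than this note shows. Statements on the series, on what has been measured and on what is new or still open speak of the compounds shown alone.

Measured compounds:
Compound 1, `COc1cc(/C=C/C(=O)c2sc(Nc3ccccc3C)nc2C)cc(OC)c1OC`, gives 6320 nM in a functional assay on NCI-H460 cells (Homo sapiens) for cytotoxicity, read by MTT assay; a lower number here means a stronger inhibitor, a higher number a weaker inhibitor.
Compound 2, `Cc1ccc(Nc2nc(C)c(C(=O)/C=C/c3ccc(Cl)cc3)s2)cc1`, gives only a limit in this assay, > 25000 nM, and not a number.

Among the two values shown, compound 1 holds the only actual number in this assay. Compound 2 sits at the limit of > 25000 nM in this assay, at which 1 of the 2 values shown sits. Compound 2 differs from compound 1 in several places at once, so its limit says nothing about any single change. Compound 3, `COc1cc(/C=C/C(=O)c2sc(Nc3ccccc3)nc2C)cc(OC)c1OC`, has not yet been measured. It differs from compound 1 by hydrogen in place of methyl on an aromatic carbon. Among the compounds with values here, no measured pair shows this change by itself, so there is no direct guide to its effect. With only a single methyl leaving, and nothing in the shown numbers pointing either way, the step is expected to stay within the usual scatter: a 1.1-fold higher number from compound 1 to compound 3 (0.04 log units; within the scatter). Compound 3 is therefore estimated at 7000 nM, with a likely range from 2500 nM to 20000 nM.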

Compound 3, half-maximal inhibitory concentration: > 25000 nM
Compound 3: a limit, no number; the forecaster's own chance of this, stated with the estimate: 15%; at least 3.5-fold (0.55 log units) between middle value and limit.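

In this assay, within the data shown here, this is the first pair of compounds that differ in one place only, and it shows that the methyl on the 2-methylphenyl group counts: going from 2-methylphenyl to phenyl gives an at least 3.9-fold higher number from compound 1 to compound 3 (0.59 log units; beyond the scatter). Compound 3 gives only a limit, > 25000 nM, and not a number. The step therefore has a lower bound but no known size: the limit of > 25000 nM in this assay, at which 2 of the 3 values shown sit.

The compounds shown cannot tell why losing this methyl weakens the compound, since a single change at one place gives no cause. On these data alone, it also stays open whether another group at the same place, such as ethyl, methoxy or chlorine, would match the number of compound 1, improve on it or fall short of it.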